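Aryl swap on the ring amine: compound 1 to compound 4

The source may report more compounds than this note shows. Statements on the series, on what has been measured and on what is new or still open speak of the compounds shown alone.

Measured in a functional assay on HeLa cells (Homo sapiens) for antiproliferative activity, read by MTT assay, with a stated time of 72 h; a lower number here means a stronger inhibitor, a higher number a weaker inhibitor:
compound 1 `Cc1ccc(N2CCN(C(=S)SCc3ccc4nc(N)nc(N)c4c3)CC2)c(C)c1` gives 3190 nM
compound 2 `Nc1nc(N)c2cc(CSC(=S)N3CCN(c4ccc(Cl)cc4)CC3)ccc2n1` gives 6990 nM
compound 3 `Nc1nc(N)c2cc(CSC(=S)N3CCN(c4ccccc4Cl)CC3)ccc2n1` gives 4050 nM

Compound 1 holds the lowest number of the three. Compound 3 sits within the scatter of it a 1.3-fold higher number from compound 1 to compound 3 (0.10 log units; within the scatter), while compound 2 lies beyond it a 2.2-fold higher number from compound 1 to compound 2 (0.34 log units; beyond the scatter); the step between compound 2 and compound 3 is within the scatter a 1.7-fold lower number from compound 2 to compound 3 (0.24 log units; within the scatter).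

Compound 4 `CC(=O)c1ccc(N2CCN(C(=S)SCc3ccc4nc(N)nc(N)c4c3)CC2)cc1` differs from compound 1 by 4-acetylphenyl in place of 2,4-dimethylphenyl on an amine nitrogen in a ring. Among the measured compounds shown here, the steps that bear on this change are those that replace the same 2,4-dimethylphenyl group on the ring amine: a 2.2-fold higher number from compound 1 to compound 2 (0.34 log units; beyond the scatter) and a 1.3-fold higher number from compound 1 to compound 3 (0.10 log units; within the scatter). One was modest and beyond the scatter, the other within it. A modest weakening is therefore expected, a 1.4-fold higher number from compound 1 to compound 4 (0.15 log units; within the scatter). Compound 4 is estimated at 4500 nM in this assay, with a range of 2200 nM to 9500 nM.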

Compound 4, half-maximal inhibitory concentration: 2040 nM
For compound 4 the middle estimate is 2.2-fold (0.34 log units) above the measured one, outside the stated range (below it).
By their numbers in this assay, from the lowest: compounds 4, 1, 3 and 2 (each within the scatter of the next, the first and the last beyond it).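

In this assay, 4-acetylphenyl on the ring amine stands within the scatter of 2,4-dimethylphenyl, a 1.6-fold lower number from compound 1 to compound 4 (0.19 log units; within the scatter), and of 2-chlorophenyl, a 2.0-fold lower number from compound 3 to compound 4 (0.30 log units; within the scatter), so the added carbonyl brings no step beyond the scatter against either group. The one clear separation is on the aromatic carbon that carries the substituent in compound 2 and compound 4, acetyl in place of chloro: a 3.4-fold lower number from compound 2 to compound 4 (0.53 log units; beyond the scatter). Nothing available explains this step.

As far as these compounds go, whether an amine or a carboxylic acid on that aromatic carbon would track acetyl or chloro remains open. Also open, from the compounds shown here alone, is how an unsubstituted phenyl would compare with these groups.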